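Removing a methoxy group across two isomeric cores

A few compounds are considered here, and "the series" means these few. Any claim that something is new, unique, unknown or untested is made for them only; others in the source may bear on it.

Compound 1 `COc1ccc2[nH]c(C)c(C3=C(Cl)C(=O)C(c4c(-c5ccc(C)cc5)[nH]c5ccccc45)=C(Cl)C3=O)c2c1` and compound 2 `Cc1ccc(-c2[nH]c3ccccc3c2C2=C(Cl)C(=O)C(c3c(C)[nH]c4ccccc34)=C(Cl)C2=O)cc1` share one core and differ only by hydrogen in place of methoxy on an aromatic carbon. In a functional assay on MDA-MB-231 cells (Homo sapiens) for antiproliferative activity, read by CCK-8 assay, with a stated time of 48 h (a lower number here means a stronger inhibitor, a higher number a weaker inhibitor), compound 1 gives 4.15 ug/mL, and compound 2 gives 4.21 ug/mL; the change made a 1.0-fold higher number from compound 1 to compound 2 (0.01 log units; within the scatter). Compound 3 `COc1ccc2[nH]c(C)c(C3=C(Cl)C(=O)C(Cl)=C(c4c(-c5ccc(C)cc5)[nH]c5ccccc45)C3=O)c2c1` carries the same methoxy-bearing indole but on a core built from the same atoms joined differently; the difference between the two cores is not broken down here. In this assay compound 3 gives 6.04 ug/mL, which sits within the scatter of both compound 1 and compound 2. Compound 4 `Cc1ccc(-c2[nH]c3ccccc3c2C2=C(Cl)C(=O)C(Cl)=C(c3c(C)[nH]c4ccccc34)C2=O)cc1` has not yet been measured; it stands to compound 3 as compound 2 stands to compound 1, differing by hydrogen in place of methoxy on an aromatic carbon, at a place described in the same words for both pairs, so this is the same change. Within the data shown here, the only guide is the earlier pair, where removing the methoxy left the number essentially unchanged. On that basis the expected step is a 1.0-fold lower number from compound 3 to compound 4 (0.00 log units; within the scatter). Compound 4 is therefore estimated at 6 ug/mL, with a range from 3.5 ug/mL to 10.5 ug/mL to allow for the fact that the change has been seen only once.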

Compound 4, half-maximal inhibitory concentration: 5.77 ug/mL
For compound 4 the middle estimate is 1.0-fold (0.02 log units) above the measured one; measured number inside the range.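

In this assay, replacing methoxy with hydrogen on the second core gives a 1.0-fold lower number from compound 3 to compound 4 (0.02 log units; within the scatter), so this change again leaves the number within the scatter. Among these compounds, the two cores therefore give the same reading for this change, and the earlier result carries over from one core to the other: the same change on two cores in this assay, a 1.0-fold higher number (0.01 log units; within the scatter) from compound 1 to compound 2 and a 1.0-fold lower number (0.02 log units; within the scatter) from compound 3 to compound 4, 1.1-fold (0.03 log units) apart, within the scatter of two such steps This shows only that the change from 5-methoxy-2-methyl-1H-indol-3-yl to 2-methyl-1H-indol-3-yl makes no measurable difference on these two cores in this one cell assay; it does not show that the methoxy would be equally dispensable on any other core, in another cell line or at another place on the ring.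

Still open, as far as these compounds go, is whether a different group at the same place, such as a hydroxyl, an amine or a carboxylic acid, would also leave the number within the scatter. Also open, from the compounds shown here alone, is whether the result would hold if the two chlorines on the core gave way to bromine or to a nitrile.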